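Swapping an ether arm for a chlorophenyl on the oxadiazole

This account rests on a few compounds, and the source may have more. Where it says the series, first, only, none or still open, it means among the compounds named here.

Three compounds share an imidazoline-bearing core and were tested in an assay for inhibition of Amine oxidase [flavin-containing] B (Homo sapiens), read by fluorescence and spectrophotometry, using microsomes, with stated times of 30 min and 20 min; a higher number here means a weaker inhibitor, a lower number a stronger inhibitor. Compound 1 `FC(F)(F)c1cnc2c(c1)Oc1ccccc1C1=NCCN12` reaches only the limit of > 100000 nM, which is a limit rather than a number. Compound 2 `c1cc(C2=NCCN2)cc(-c2noc(-c3cccs3)n2)c1` gives 1060 nM. Compound 3 `c1ccc(OCc2noc(-c3ccc(C4=NCCN4)cc3)n2)cc1` gives 9980 nM, the highest of the two numbers, and its gap to compound 2 lies beyond the usual scatter. Compound 4 `Clc1ccccc1-c1noc(-c2ccc(C3=NCCN3)cc2)n1` changes compound 3 by 2-chlorophenyl in place of phenoxymethyl on an aromatic carbon, putting a 2-chlorophenyl directly on the ring, as compound 2 carries an aromatic ring there. A step toward a lower number is expected in this assay, estimated as a 4.0-fold lower number from compound 3 to compound 4 (0.60 log units; beyond the scatter). Compound 4 is therefore expected to give about 2500 nM, within 600 nM to 12000 nM.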

Compound 4, half-maximal inhibitory concentration: 30 nM
For compound 4 the middle estimate is 83-fold (1.92 log units) above the measured one; measured number outside the range, below it.
By their numbers in this assay, from the lowest: compound 4; then compound 2; then compound 3. At a limit, above all of these: compound 1.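

This position, the aromatic carbon between two ring nitrogen atoms, proves highly sensitive in this assay: 2-chlorophenyl in place of phenoxymethyl gives a 330-fold lower number from compound 3 to compound 4 (2.52 log units; beyond the scatter). Both groups carry a six-membered aromatic ring of carbon only, so a large step can arise even when that ring is kept. Nothing shown here accounts for the size of this step.

Going by these compounds, whether the chlorine or the removal of the oxygen-containing link matters more stays open, as the change alters both at once. A plain phenyl group at this carbon would separate the two, and an amine there remains untested among the compounds shown.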